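Trading a Methoxyphenyl Arm for Bromine

The source may hold more compounds than are shown below. What is called first, only, known or untested is meant among the compounds shown, and "the series" means these compounds.

Measured so far in a functional assay on DLD-1 cells (Homo sapiens) for antiproliferative activity, read by CellTiter-Glo, with a stated time of 72 h; on this read-out lower numbers stand for stronger inhibition and higher numbers for weaker inhibition:
Compound 1 `COc1ccc(-c2cccc(S(=O)(=O)N3CCC(N4CCC(C)CC4)CC3)c2)cc1` gives 23 nM.
Compound 2 `Cc1cc(C)c(S(=O)(=O)c2ccc(N3CCC(C)CC3)cc2)c(C)c1` gives > 5000 nM, which is a limit of this assay and not a number.

Compound 1 thus holds the only plain number shown; the other value is the limit (the limit of > 5000 nM in this assay, at which 1 of the 2 values shown sits). Compound 3 `CC1CCN(C2CCN(S(=O)(=O)c3cccc(Br)c3)CC2)CC1` differs from compound 1 by bromo in place of 4-methoxyphenyl on an aromatic carbon. For the measured compounds named here, no step between measured compounds is recorded, so the move from compound 1 to compound 3 is expected to weaken inhibition in this assay by more than the usual scatter, as a guess: a 17-fold higher number from compound 1 to compound 3 (1.24 log units; beyond the scatter). Compound 3 is estimated at 400 nM, ranging from 60 nM to 3000 nM.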

Compound 3, half-maximal inhibitory concentration: 3.2 nM
Estimate against measurement, compound 3: 130-fold (2.10 log units) above; the measured number lies below the stated range.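

Swapping 4-methoxyphenyl for bromo gives a 7.2-fold lower number from compound 1 to compound 3 (0.86 log units; beyond the scatter) in this assay. Strong inhibition at this place on the aromatic ring therefore does not depend on keeping the 4-methoxyphenyl ring, and a single bromine atom does better here, although this rests on one pair of compounds. Nothing measured here gives a reason for the gain.

The compounds shown leave open whether bromo itself matters, or whether chlorine, a nitrile or a plain hydrogen at the same place would serve as well.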